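The source may hold more compounds than are shown below. What is called first, only, known or untested is meant among the compounds shown, and "the series" means these compounds.

In a functional assay on M21 cells (Homo sapiens) for antiproliferative activity, read by sulforhodamine B assay, with a stated time of 48 h (on this read-out lower numbers stand for stronger inhibition and higher numbers for weaker inhibition), the series so far reads:

Compound 1 `O=C1NCCN1c1ccc(S(=O)(=O)Nc2ccc(F)cc2)cc1` gives 230 nM
Compound 2 `O=C1NCCN1c1ccc(S(=O)(=O)Nc2ccc(I)cc2)cc1` gives 260 nM
Compound 3 `O=C1NCCN1c1ccc(S(=O)(=O)Nc2ccc(Cl)cc2)cc1` gives 90 nM

Compound 3 holds the lowest number of the three. Compound 4 `CC(C)Cc1ccc(NS(=O)(=O)c2ccc(N3CCNC3=O)cc2)cc1` is not yet measured and differs from it by isobutyl in place of chloro on an aromatic carbon in the one place that varies, with isobutyl in place of chloro on an aromatic carbon.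

Among the compounds with values here, three measured steps bear on this change, all exchanges of one halogen for another. Fluoro and iodo do not separate, with a 1.1-fold higher number from compound 1 to compound 2 (0.05 log units; within the scatter) as the step between them. Chloro stands apart, with a 2.6-fold lower number from compound 1 to compound 3 (0.41 log units; beyond the scatter) and a 2.9-fold lower number from compound 2 to compound 3 (0.46 log units; beyond the scatter) as modest steps. No alkyl group has been measured here, so these steps give only a rough size. Both other groups give higher numbers than chloro, with compound 1 at 230 nM and compound 2 at 260 nM in that comparison. A modest move to a higher number is therefore expected, and the estimated change is a 3.3-fold higher number from compound 3 to compound 4 (0.52 log units; beyond the scatter) on this reasoning. Compound 4 is expected at 300 nM in this assay within an estimated range of 100 nM to 900 nM for now.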

Compound 4, half-maximal inhibitory concentration: > 1000 nM
Compound 4: a limit, no number; the forecaster's own chance of this, stated with the estimate: 3%; middle value at least 3.3-fold (0.52 log units) from the limit.
By their numbers in this assay, from the lowest: compound 3; then compounds 1 and 2 (each within the scatter of the next). At a limit, above all of these: compound 4.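

In this assay compound 4 gives only a limit and not a number, so the isobutyl group can be bounded at this position but not sized: the limit of > 1000 nM in this assay, at which 1 of the 4 values shown sits. Replacing chloro with isobutyl gives an at least 11-fold higher number from compound 3 to compound 4 (1.04 log units; beyond the scatter), a large step, whereas the exchanges among the halogens stayed modest or within the scatter. The isobutyl group also separates from the two halogens with the higher numbers, with an at least 3.8-fold higher number from compound 2 to compound 4 (0.58 log units; beyond the scatter) and an at least 4.3-fold higher number from compound 1 to compound 4 (0.63 log units; beyond the scatter), so compound 4 stands apart from all three halogen compounds and not from chloro alone.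

The compounds shown leave open how far beyond its limit compound 4 lies, and whether a methyl group or a longer chain would read like isobutyl. From the compounds shown here alone, how an amine or a carboxylic acid would read at this place also remains open.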